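The compounds below may be only part of what the source reports. "The series", "measured", "known", "first", "only" and "open" are said of these compounds alone.

The study concerns two compounds that have already been tested in an assay on isolated protein for inhibition of hexokinase-2 (Rattus norvegicus), with a stated time of 6 h, tested at 10 mM; on this read-out lower numbers stand for less inhibition and higher numbers for more inhibition at the one concentration tested (going by the name of the read-out). Compound 1 `O=C(CI)NCCCC(=O)NCCCCCCNc1ncnc2c1ncn2[C@@H]1O[C@H](COP(=O)(O)OP(=O)(O)OP(=O)(O)O)[C@@H](O)[C@H]1O` gives 0% in this assay, and compound 2 `CN(CCCN(C)C(=O)CCCNc1ncnc2c1ncn2[C@@H]1O[C@H](COP(=O)(O)OP(=O)(O)OP(=O)(O)O)[C@@H](O)[C@H]1O)C(=O)CCCNC(=O)CI` gives 0% in this assay. On the numbers shown, compound 1 stands level with compound 2 at the digits printed, and no step between the two is set out, so only their two values speak: both report no measurable inhibition at the one concentration tested.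

Compound 3 `O=C(CI)NCCC(=O)NCCCCCCNc1ncnc2c1ncn2[C@@H]1O[C@H](COP(=O)(O)OP(=O)(O)OP(=O)(O)O)[C@@H](O)[C@H]1O` has not yet been measured in this assay. It differs from compound 1 in one place: ((iodomethyl)carbonyl)amino in place of (((iodomethyl)carbonyl)amino)methyl on a saturated chain carbon, two bonds along the chain from a carbonyl carbon. The chain that carries the iodomethyl carbonyl amino end is thus one carbon shorter, while the shared core and the linker on its far side are kept as they are in compound 1.

Compound 2, which carries a quite different chain, also reads as no inhibition in this assay. No step beyond the scatter is expected for no change at the digits printed from compound 1 to compound 3 (within the scatter), because compound 1 gives 0% in this assay. Compound 3 is therefore expected to give 0% in this assay, within a range from 0% to 10%.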

Compound 3, a percentage reported as inhibition, at one concentration (the size of the read-out at that concentration, not a potency): 0%
For compound 3 middle estimate and measured number coincide at the digits printed, within the range that was stated.
By their numbers in this assay, from the lowest: compounds 1, 2 and 3 (each within the scatter of the next).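

Going from (((iodomethyl)carbonyl)amino)methyl to ((iodomethyl)carbonyl)amino on a saturated chain carbon, two bonds along the chain from a carbonyl carbon, gives in this assay no change at the digits printed from compound 1 to compound 3 (within the scatter). Within the data shown here, this is the first reading of a change in one place at this position, and it shows that taking one carbon out of the chain that carries the iodomethyl carbonyl amino end does not bring inhibition into view at the one concentration tested. Since the read-out shows no inhibition at either end of the step, it cannot tell whether this position matters to inhibition of the protein, and nothing at hand accounts for the result.

The compounds shown leave open whether any change at this position can raise the read-out in this assay, for example a longer chain, an amine on the same carbon or a chloromethyl group in place of the iodomethyl. Among these compounds, they also leave open how the chain on the far side of the amide affects the read-out, since no step at that place can be read from these compounds.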